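Changing the aromatic group on compound 2

This account rests on a few compounds, and the source may have more. Where it says the series, first, only, none or still open, it means among the compounds named here.

Values from a functional assay on NCI/ADR cells (Homo sapiens) for cytotoxicity, read by sulforhodamine B assay (a lower number here means a stronger inhibitor of growth, a higher number a weaker inhibitor of growth), for the measured compounds:
Compound 1 `CC1=CC[C@@H]([C@@](C)(O)CCCC(C)(C)NC=S)CC1` gives 16700 nM
Compound 2 `COc1ccc(/C=N\NC(=S)NC(C)(C)CCC[C@](C)(O)[C@@H]2CC=C(C)CC2)cc1` gives 6730 nM
Compound 3 `CC1=CC[C@@H]([C@@](C)(O)CCCC(C)(C)NC(=S)N/N=C\c2ccc(O)cc2)CC1` gives 8390 nM

Compound 2 sits level with compound 3, and it lies beyond the scatter from compound 1, whose number is the higher. Compound 4 `CC1=CC[C@@H]([C@@](C)(O)CCCC(C)(C)NC(=S)N/N=C\c2cccc([N+](=O)[O-])c2)CC1` keeps the shared core and changes one group: 3-nitrophenyl in place of 4-methoxyphenyl on a carbon with a double bond to nitrogen. In words, this is 3-nitrophenyl in place of 4-methoxyphenyl on a carbon with a double bond to nitrogen.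

For the measured compounds named here, no measured compound carries 3-nitrophenyl, so the data offer no direct guide. Going by the values given here, the closest evidence is the one measured change on this aromatic ring, hydrogen in place of methyl on an oxygen, which gave a 1.2-fold higher number from compound 2 to compound 3 (0.10 log units; within the scatter). That is a single small step, and it makes a weak basis for a larger swap. With nothing pointing either way, no shift beyond the scatter is expected in this assay, and the uncertainty remains wide. The expected change is a 1.1-fold higher number from compound 2 to compound 4 (0.05 log units; within the scatter). For compound 4 the estimated value is 7500 nM, with an expected range of 3500 nM to 15000 nM.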

Compound 4, concentration for 50% growth inhibition: 6720 nM
Compound 4: the middle estimate sits 1.1-fold (0.05 log units) above what was measured; the measured number falls inside the stated range.
By their numbers in this assay, from the lowest: compounds 4, 2, 3 and 1 (each within the scatter of the next, the first and the last beyond it).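

In this assay, replacing the whole aromatic group on the carbon with a double bond to nitrogen leaves no readable change: 3-nitrophenyl in place of 4-methoxyphenyl gives (a 1.0-fold lower number from compound 2 to compound 4 (0.00 log units; within the scatter)), and 3-nitrophenyl in place of 4-hydroxyphenyl gives (a 1.2-fold lower number from compound 3 to compound 4 (0.10 log units; within the scatter)). Compounds 2 and 3 showed only a small edit on the oxygen of a single ring substituent, whereas compound 4 carries a different group at a different ring position, as the names 4-methoxyphenyl and 3-nitrophenyl show. Across these three aromatic groups, then, this place accepts a larger change than the earlier pair could reveal, without any shift beyond the scatter, and nothing in the available data accounts for this steadiness.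

Still open, on these data alone, is whether any group at this place can move the number beyond the scatter, since all three compounds compared here carry a substituted phenyl ring. A phenyl ring bearing an amine or a carboxylic acid, or a plain alkyl chain in place of the ring, would test how far this tolerance extends.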